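The source may report more compounds than this note shows. Statements on the series, on what has been measured and on what is new or still open speak of the compounds shown alone.

Working notes on the series.

Compound 1 `Cc1cc(O)c(C(=O)/C=C/c2ccc(Br)cc2)c(-c2ccccc2)c1C(=O)/C=C/c1ccc(Br)cc1` is the reference point. In a functional assay on MDA-MB-231 cells (Homo sapiens) for cytotoxicity, read by MTT assay, with a stated time of 24 h (on this read-out higher numbers stand for weaker inhibition and lower numbers for stronger inhibition), compound 1 gives 10000 nM. Compound 3 `Cc1cc(O)c(C(=O)/C=C/c2ccc(Cl)cc2)c(-c2ccc(Br)cc2)c1C(=O)/C=C/c1ccc(Cl)cc1` gives 15000 nM in this assay. Compound 2 `Cc1cc(O)c(C(=O)/C=C/c2ccc3ccccc3c2)c(-c2ccc(Cl)cc2)c1C(=O)/C=C/c1ccc2ccccc2c1` is recorded in this assay as "not active" (no number reported), with no number attached. Of the two numbers on hand, compound 1 holds the smaller one, but its gap to compound 3 lies within the usual scatter, so the two cannot be set apart on these data.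

Compound 4 `Cc1cc(O)c(C(=O)/C=C/c2ccc(Br)cc2)c(-c2ccc(OCc3ccccc3)cc2)c1C(=O)/C=C/c1ccc(Br)cc1` has not been measured. It differs from compound 1 by benzyloxy in place of hydrogen on an aromatic carbon, para to a large group. Among the measured compounds shown here, no measured pair in the set shows this change, so there is nothing to size it from. The expected step of a 1.2-fold higher number from compound 1 to compound 4 (0.08 log units; within the scatter) stays within the scatter, with no direction favoured. For compound 4 the estimate in this assay is 12000 nM, ranging from 4000 nM to 35000 nM.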

Compound 4, half-maximal inhibitory concentration: 30000 nM
Beside the measured number, compound 4's estimate is 2.5-fold (0.40 log units) below it; the measured number falls inside the stated range.
By their numbers in this assay, from the lowest: compounds 1, 3 and 4 (each within the scatter of the next, the first and the last beyond it).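

Benzyloxy in place of hydrogen on an aromatic carbon, para to a large group, is the first single-place change in the series that can be sized. In this assay it gives a modest step beyond the scatter (a 3.0-fold higher number from compound 1 to compound 4 (0.48 log units; beyond the scatter)), and on this read-out the higher number stands for weaker inhibition. This position therefore responds to substitution, and here the benzyloxy group is not an improvement, though no measurement on hand bears on the reason for the step.

A single step gives neither a trend nor a way to separate the contribution of the ether oxygen from that of the added aromatic ring. As far as these compounds go, whether methoxy, an amine or a carboxylic acid at the same place would move the number in the same direction remains open.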